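Compound 1 to compound 3: phenoxy in place of vinyl

This account rests on a few compounds, and the source may have more. Where it says the series, first, only, none or still open, it means among the compounds named here.

Working values in a functional assay on HL-60 cells (Homo sapiens) for inhibition, read by resazurin assay, with a stated time of 72 h; a higher number here means a weaker inhibitor, a lower number a stronger inhibitor:
- compound 1 `C=CC1C(=O)N(c2cc(OC)c(OC)c(OC)c2)C1c1ccc(SC)cc1`: 61 nM
- compound 2 `C=CC1C(=O)N(c2cc(OC)c(OC)c(OC)c2)C1c1ccc(SCC)cc1`: 320 nM
- compound 3 `COc1cc(N2C(=O)C(Oc3ccccc3)C2c2ccc(SC)cc2)cc(OC)c1OC`: not yet measured

Going by the values given here, compound 1 has the lower of the two numbers so far. The next change is phenoxy in place of vinyl on a saturated ring carbon. Among the compounds with values here, no measured step covers this place. Within the data shown here, the only step, a 5.2-fold higher number from compound 1 to compound 2 (0.72 log units; beyond the scatter), is methyl in place of hydrogen on a saturated chain carbon bound to a sulfur, so it is a weak guide. On that step alone, a modest rise is expected in this assay. The expected step is a 3.3-fold higher number from compound 1 to compound 3 (0.52 log units; beyond the scatter). Compound 3 is estimated at 200 nM, with an expected range of 30 nM to 1200 nM.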

Compound 3, half-maximal inhibitory concentration: 388 nM
Estimate against measurement, compound 3: 1.9-fold (0.29 log units) below; the measured number falls inside the stated range.
By their numbers in this assay, from the lowest: compound 1; then compounds 2 and 3 (each within the scatter of the next).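

Replacing vinyl with phenoxy on the saturated ring carbon of the four-membered ring gives, in this assay, a 6.4-fold higher number from compound 1 to compound 3 (0.80 log units; beyond the scatter), so this position responds to substitution and the larger aromatic group does not match vinyl. Activity remains measurable with phenoxy present, and the step is the only reading at this position. No supporting measurement accounts for the change. The compounds shown leave open whether the loss follows from the oxygen link or the phenyl ring. Methoxy, benzyl or an amine at this carbon would separate those two parts.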